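Anilide for propylamide on the dihydrofuran carboxamide core

The source may hold more compounds than are shown below. What is called first, only, known or untested is meant among the compounds shown, and "the series" means these compounds.

Measured compounds:
compound 1 `C=CC1=C(C(=O)NCCC)C(c2ccc(Cl)c(Cl)c2)OC1`, 31300 nM
compound 2 `C=CC1=C(C(=O)NC(C)(C)C)C(c2ccc(OC)cc2)OC1`, > 100000 nM
compound 3 `C=CC1=C(C(=O)NCc2ccc(Cl)cc2)C(c2ccc(F)cc2)OC1`, 36900 nM

The read-out is a functional assay on QGY7701 cells (Homo sapiens) for cytotoxicity, read by MTT assay, with a stated time of 24 h; a higher number here means a weaker inhibitor, a lower number a stronger inhibitor. In this assay compound 1 gives 31300 nM. Compound 3, with 36900 nM, sits within the scatter of compound 1, so the two cannot be told apart. The value of compound 2, > 100000 nM, is a limit of the assay and not a number; at that limit (the limit of > 100000 nM in this assay, at which 1 of the 3 values shown sits).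

Compound 4 `C=CC1=C(C(=O)Nc2ccccc2)C(c2ccc(Cl)c(Cl)c2)OC1` keeps the core of compound 1, including the dichlorophenyl group, and differs only in the amide: phenyl in place of propyl on an amide-type nitrogen. Going by the values given here, no step between two measured compounds isolates this change, so the size of its effect is unknown. Compound 3 carries an aromatic group on the same nitrogen, one bond further out, and its value lies within the scatter of compound 1, which is the only hint available. The step from compound 1 to compound 4 is therefore expected to be a 1.0-fold lower number from compound 1 to compound 4 (0.02 log units; within the scatter), that is, nothing clearly beyond the scatter. Compound 4 is estimated at 30000 nM, with a range from 8000 nM to 100000 nM.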

Compound 4, half-maximal inhibitory concentration: > 100000 nM
Compound 4 ended at the assay's limit; the forecaster's own chance of this, stated with the estimate: 25%; at least 3.3-fold (0.52 log units) between middle value and limit.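

In this assay, phenyl in place of propyl on an amide-type nitrogen gives an at least 3.1-fold higher number from compound 1 to compound 4 (0.50 log units; beyond the scatter), so the amide substituent on the core of compound 1 matters to this read-out. This is the only step shown that isolates that substituent with the dichlorophenyl group held fixed, whereas compound 1, compound 2 and compound 3 differ from one another in more than one place. The value of compound 4 is a limit of the assay and not a number, so the full size of the step cannot be read: the limit of > 100000 nM in this assay, at which 2 of the 4 values shown sit.

On these data alone, it remains open whether the change follows from the ring itself or from its attachment directly to the nitrogen, which an unsubstituted benzyl group on that nitrogen, with the dichlorophenyl group kept, would help separate. As far as these compounds go, how a longer chain such as pentyl, or a chain ending in an amine, would compare with propyl also remains open.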